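The source may report more compounds than this note shows. Statements on the series, on what has been measured and on what is new or still open speak of the compounds shown alone.

Measured compounds:
- compound 1, `COc1cc(Cc2nc3c(N)ncnc3n2CC(C)CO)cc(OC)c1OC`: in a functional assay on MCF7 cells (Homo sapiens) for cytotoxicity (on this read-out lower numbers stand for an effect already at smaller amounts and higher numbers for an effect only at larger amounts of compound), compound 1 gives 49100000 nM
- compound 2, `CCCCCCn1c(Cc2cc(OC)c(OC)c(OC)c2)nc2c(N)nc(F)nc21`: in this assay compound 2 gives 112000000 nM

Compound 2 stands at the highest number of the two, which means that its effect on the cells appears only at the larger amount. Its nearest neighbour is compound 1, whose number is lower, and that gap lies beyond the usual scatter of this kind of measurement. The two compounds differ in more than one place, so nothing can be said about which part of the change accounts for the gap.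

Compound 3, `C=CCCn1c(Cc2cc(OC)c(OC)c(OC)c2)nc2c(N)nc(F)nc21`, is not yet measured. It differs from compound 2 in a single place: vinyl in place of butyl on a saturated chain carbon, two bonds along the chain from an aromatic nitrogen. The chain that hangs from the core is thus shortened and given a double bond at its end, while everything else stays as it is. Among the compounds with values here, no step of this kind is known among the measured compounds, so the expectation rests on the change being small and confined to the chain. The expected step is a 1.1-fold lower number from compound 2 to compound 3 (0.05 log units; within the scatter). For compound 3 the number is estimated at 100000000 nM, with a range from 40000000 nM to 250000000 nM.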

Compound 3, half-maximal effective concentration: 102000000 nM
Beside the measured number, compound 3's estimate is 1.0-fold (0.01 log units) below it; the range from low to high includes it.
By their numbers in this assay, from the lowest: compound 1; then compounds 3 and 2 (each within the scatter of the next).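

In this assay, within the data shown here, putting vinyl in place of butyl on a saturated chain carbon, two bonds along the chain from an aromatic nitrogen, gives a 1.1-fold lower number from compound 2 to compound 3 (0.04 log units; within the scatter), and this is the first comparison here in which only one place differs. Read one bond further out, the same difference is hexyl to but-3-en-1-yl, so at this position a group of 4 heavy atoms can give way to one of 2 heavy atoms carrying 1 double bond with no change that stands out from the scatter of this measurement. The data available here offer nothing that bears on why the chain change leaves the read-out where it is.

The shorter chain and its double bond arrive together, so the compounds shown cannot tell whether each alone would also leave the number in place, a question that a fully saturated chain of the same length as in compound 3 would address. Going by these compounds, how far this tolerance extends also stays open, since a much longer chain, or an amine or a carboxylic acid carried on this chain, might behave quite differently.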